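The source may report more compounds than this note shows. Statements on the series, on what has been measured and on what is new or still open speak of the compounds shown alone.

For the measured compounds named here, compound 2 `COc1ccc(C(=O)/C=C/c2cc(-c3cc(OC)c(OC)c(OC)c3)n[nH]2)cc1OC` gives -98% in a functional assay on HOP-62 cells (Homo sapiens) for cytotoxicity, read by sulforhodamine B assay, with a stated time of 48 h, tested at 100 uM (on this read-out lower numbers stand for a stronger effect and higher numbers for a weaker effect at the one concentration tested), the lowest of the two numbers measured so far; compound 1 `COc1cc(-c2cc(/C=C/C(=O)c3ccc(Cl)c(Cl)c3)[nH]n2)cc(OC)c1OC` gives -74%, and the step of a number 24 percentage points lower from compound 1 to compound 2 (beyond the scatter) is the only change recorded. Compound 3 `COc1cc(C(=O)/C=C/c2cc(-c3cc(OC)c(OC)c(OC)c3)n[nH]2)cc(OC)c1OC` differs from compound 2 by methoxy in place of hydrogen on an aromatic carbon. Going by the values given here, that change falls on the same ring that was swapped between compound 1 and compound 2, yet no measured step adds a single methoxy to it, so the guidance is indirect. Compound 3 is therefore expected to give about -98%, between -108% and -84%. The expected step is no change at the digits printed from compound 2 to compound 3 (within the scatter), within the scatter.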

Compound 3, a percentage reported as activity, at one concentration (the size of the read-out at that concentration, not a potency): -100%
The estimate for compound 3 lay 2 percentage points above the measured number; measured number inside the range.
By their numbers in this assay, from the lowest: compounds 3 and 2 (each within the scatter of the next); then compound 1.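

In this assay, methoxy in place of hydrogen on an aromatic carbon gives a number 2 percentage points lower from compound 2 to compound 3 (within the scatter), so compound 2 and compound 3 cannot be told apart. The earlier step exchanged two groups on this ring at once, whereas this one shows that the position, ortho to a methoxy group, carries one more methoxy with the read-out staying alike. Nothing available explains this result. As far as these compounds go, whether a hydroxyl, an amine or a carboxylic acid at this position would read the same remains open. So does whether compound 2 and compound 3 would separate at a lower concentration.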